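Ethylsulfonyl Variant in a Cyclopropyl Ether Agonist Series

The compounds below may be only part of what the source reports. "The series", "measured", "known", "first", "only" and "open" are said of these compounds alone.

Measured in a functional assay on isolated protein for agonist activity at Glucose-dependent insulinotropic receptor (Mus musculus), read by cAMP accumulation; a lower number here means that less compound is needed, a higher number that more compound is needed for the effect:
Compound 1 `COc1cnc(N2CCC([C@H]3C[C@H]3COCc3ccc(S(C)(=O)=O)cc3F)CC2)nc1`: 1.4 nM
Compound 2 `COCc1cnc(N2CCC([C@H]3C[C@H]3COCc3ccc(S(C)(=O)=O)cc3F)CC2)nc1`: 1.9 nM

Compound 2 holds the higher of the two numbers, but the step of a 1.4-fold higher number from compound 1 to compound 2 (0.13 log units; within the scatter) lies within the scatter, so the two compounds are not distinguished. Compound 3 `CCS(=O)(=O)c1ccc(COC[C@@H]2C[C@@H]2C2CCN(c3ncc(COC)cn3)CC2)c(F)c1` differs from compound 2 by methyl in place of hydrogen on a saturated chain carbon bound to a sulfonyl sulfur. For the measured compounds named here, no measured step touches the sulfonyl end of the molecule; the single known step, a 1.4-fold higher number from compound 1 to compound 2 (0.13 log units; within the scatter), concerns the other end and is itself within the scatter. Compound 3 is therefore expected to remain close to compound 2. The expected step is a 1.3-fold higher number from compound 2 to compound 3 (0.12 log units; within the scatter). The estimate for compound 3 is 2.5 nM, ranging from 1 nM to 6 nM.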

Compound 3, half-maximal effective concentration: 12.5 nM
Beside the measured number, compound 3's estimate is 5.0-fold (0.70 log units) below it, outside the stated range (above it).
By their numbers in this assay, from the lowest: compounds 1 and 2 (each within the scatter of the next); then compound 3.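

In this assay the sulfonyl end turns out to respond to a small change: going from methylsulfonyl to ethylsulfonyl gives a 6.6-fold higher number from compound 2 to compound 3 (0.82 log units; beyond the scatter) and so needs more compound for the effect. The earlier step at the other end of the molecule, a 1.4-fold higher number from compound 1 to compound 2 (0.13 log units; within the scatter), did not separate its two compounds, so this position is the first shown to distinguish compounds. No measurement at hand accounts for the step. As far as these compounds go, whether a longer chain such as propyl, or an amine, on the sulfonyl sulfur would raise the number further stays open, as does whether ethylsulfonyl behaves alike with the methoxy group of compound 1.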